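The compounds below may be only part of what the source reports. "The series", "measured", "known", "first", "only" and "open" are said of these compounds alone.

Of the compounds shown here, three that share one core have been measured in an ADME assay on MDCK cells (Canis lupus familiaris) for permeability, in the apical to basolateral direction; on this read-out higher numbers stand for higher permeability and lower numbers for lower permeability. Compound 1 (`CC(C)[C@@H](c1ccc(-c2ccc3cccc(F)c3c2)[nH]c1=O)[C@@H]1OC(=O)NC1=O`) gives 3.15 10^-6 cm/s, the lowest of the three numbers. Compound 2 (`CC(C)/C(=C1\C(=O)NC(=O)N1C)c1ccc(-c2ccc3cccc(F)c3c2)[nH]c1=O`) gives 6.85 10^-6 cm/s, the closest value to that of compound 1, yet still beyond the usual scatter from it. Compound 3 (`CC(C)/C(=C1/SC(=O)NC1=O)c1ccc(-c2ccc3cccc(F)c3c2)[nH]c1=O`) gives 22.9 10^-6 cm/s, the furthest from compound 1 and also beyond the scatter.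

Compound 4 (`CC(C)[C@@H](c1ccc(-c2ccc3cccc(F)c3c2)[nH]c1=O)[C@H]1OC(=O)NC1=O`) has not yet been measured in this assay. Set against compound 1, it shows the two compounds have the same atoms and bonds and differ only in configuration as drawn: 1 of 2 stereo elements differ; a stereocentre at a saturated ring carbon is drawn S in compound 1 and R in compound 4: the two compounds have the same atoms and bonds, and a stereocentre at a saturated ring carbon is drawn S in compound 1 and R in compound 4. Going by the values given here, no measured pair in this set differs in one place only, so the data give no direct guide to the size of such a change. The expectation therefore starts from compound 1 at 3.15 10^-6 cm/s, and no step beyond the scatter is expected, with neither direction favoured. The estimated step, a 1.1-fold higher number from compound 1 to compound 4 (0.06 log units; within the scatter), is expected to remain within the scatter. Compound 4 is expected at 3.6 10^-6 cm/s, with an estimated range from 1.5 10^-6 cm/s to 8.5 10^-6 cm/s.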

Compound 4, apparent permeability: 9.14 10^-6 cm/s
The estimate for compound 4 lay 2.5-fold (0.40 log units) below the measured number; the whole stated range lies below it.
By their numbers in this assay, from the lowest: compound 1; then compounds 2 and 4 (each within the scatter of the next); then compound 3.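

Changing only the drawn configuration at a stereocentre at a saturated ring carbon, from S to R, gives a 2.9-fold higher number from compound 1 to compound 4 (0.46 log units; beyond the scatter) in this assay. Going by these compounds alone, this is the first pair in the set that differs in one place only, so it gives the first direct reading of any single change on this core, and it shows that the read-out can move beyond the usual scatter with nothing entering or leaving the structure. The step can be put down to configuration alone because nothing else separates the pair: the fact that compounds 1 and 4 differ only in the configuration as drawn

The compounds shown do not tell whether the other stereo element, drawn alike in compound 1 and compound 4, would matter as much, since no pair changes it on its own. They also leave open how the read-out would respond with an amine or a carboxylic acid on that saturated ring carbon, and whether the difference between the S and R forms would hold with such a group in place.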